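The compounds below may be only part of what the source reports. "The series", "measured", "known", "first", "only" and "open" are said of these compounds alone.

Measured so far:
Compound 1, `Cc1ccc(Nc2cc(NC(=O)Nc3c(Cl)cccc3Cl)ncn2)cc1F`, gives 85.3% in a functional assay on HCC827 cells (Homo sapiens) for inhibition, read by MTT assay, with a stated time of 48 h, tested at 10 uM; a lower number here means less inhibition, a higher number more inhibition at the concentration tested (going by the name of the read-out).
Compound 2, `COc1ccc(F)cc1Nc1cc(NC(=O)Nc2c(Cl)cccc2Cl)ncn1`, gives 78% in this assay.
Compound 3, `Cc1ccc(Nc2cc(NC(=O)Nc3c(Cl)cccc3Cl)ncn2)cc1C`, gives 84.3% in this assay.

Compound 3 stands second highest of the three numbers, but all three lie within the usual scatter of one another: a number 1 percentage points lower from compound 1 to compound 3 (within the scatter) and a number 6.3 percentage points higher from compound 2 to compound 3 (within the scatter), both inside the scatter, so no order among them can be read off. The same holds for a number 7.3 percentage points lower from compound 1 to compound 2 (within the scatter).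

Compound 4, `Cc1cc(F)cc(Nc2cc(NC(=O)Nc3c(Cl)cccc3Cl)ncn2)c1`, has not yet been measured in this assay. It differs from compound 3 in one place: 3-fluoro-5-methylphenyl in place of 3,4-dimethylphenyl on a nitrogen on an aromatic ring. For the measured compounds named here, the steps that bear on this are the exchanges of the whole aryl group on that nitrogen, a number 7.3 percentage points lower from compound 1 to compound 2 (within the scatter) and a number 6.3 percentage points higher from compound 2 to compound 3 (within the scatter), and the single swap of fluoro for methyl on an aromatic carbon, a number 1 percentage points lower from compound 1 to compound 3 (within the scatter). Every one of them stays within the scatter. On that basis the expected step is a number 2.3 percentage points lower from compound 3 to compound 4 (within the scatter), i.e. nothing beyond the scatter, in no firm direction. Compound 4 is therefore estimated at 82% in this assay, with a range from 70% to 92%.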

Compound 4, a percentage reported as inhibition, at one concentration (the size of the read-out at that concentration, not a potency): 49.1%
The estimate for compound 4 lay 32.9 percentage points above the measured number; measured number below the stated range.
By their numbers in this assay, from the lowest: compound 4; then compounds 2, 3 and 1 (each within the scatter of the next).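

In this assay, the position on a nitrogen on an aromatic ring turns out to be sensitive to the aryl group it carries, which the earlier exchanges, all within the scatter, gave no sign of: 3-fluoro-5-methylphenyl in place of 3,4-dimethylphenyl gives a number 35.2 percentage points lower from compound 3 to compound 4 (beyond the scatter) and in place of 5-fluoro-2-methoxyphenyl gives a number 28.9 percentage points lower from compound 2 to compound 4 (beyond the scatter). The sharpest comparison is with 3-fluoro-4-methylphenyl, which holds the same fluoro and methyl groups and the same count of heavy atoms, yet the exchange gives a number 36.2 percentage points lower from compound 1 to compound 4 (beyond the scatter), so at this position the arrangement of the two groups on the ring matters in this series and not merely their identity. For the compounds shown here, nothing measured so far accounts for this fall.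

Going by these compounds alone, compound 4 is the only compound with this arrangement, so it stays open whether the fall follows the fluoro, the methyl or the pair of them together. Also open, going by these compounds, is how this position responds to a group of another kind on the aryl ring, such as an amine, a hydroxyl or a longer chain like propyl.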